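This account rests on a few compounds, and the source may have more. Where it says the series, first, only, none or still open, it means among the compounds named here.

Measured so far in an ADME assay on HeLa cells (Homo sapiens) for cytotoxicity, read by resazurin assay, with a stated time of 2 days; on this read-out higher numbers stand for weaker inhibition and lower numbers for stronger inhibition:
Compound 1 `Cn1c([N+](=O)[O-])cnc1/C=C/c1ccccc1Cl`: > 100000 nM
Compound 2 `Cc1ccc(C(O)C(O)c2ncc([N+](=O)[O-])n2C)cc1`: > 100000 nM

Compound 2 gives > 100000 nM in this assay, which is a limit of the assay and not a number. Compound 1 gives > 100000 nM, which is also a limit. The whole record so far is the limit of > 100000 nM in this assay, at which 2 of the 2 values shown sit.

Compound 3 `Cn1c([N+](=O)[O-])cnc1C(O)C(O)c1ccc(Br)cc1` differs from compound 2 in one place: bromo in place of methyl on an aromatic carbon. This is bromo in place of methyl on an aromatic carbon, para to a large group. Going by the values given here, no measured pair differs in one place, so the size of this change has no direct guide. Going by compound 2 at > 100000 nM, no shift beyond the usual scatter is expected in this assay, in either direction. The estimated move, a number no higher from compound 2 to compound 3 (the limit leaves the size open), is expected to be small. Compound 3 is expected at 100000 nM, within an estimated range of 30000 nM to 200000 nM.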

Compound 3, half-maximal inhibitory concentration: 91200 nM
The estimate for compound 3 lay 1.1-fold (0.04 log units) above the measured number, within the range that was stated.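

Bromo in place of methyl on an aromatic carbon, para to a large group, gives the first true number in this assay, where compound 3 reads 91200 nM. The swap brings an at least 1.0-fold lower number from compound 2 to compound 3 (0.04 log units; that floor lies within the scatter). Going by these compounds, compound 2 carries only a limit, so that step is a floor and its true size stays open, and most of the record still rests on one limit: the limit of > 100000 nM in this assay, at which 2 of the 3 values shown sit.

The compounds shown leave open how an amine or a carboxylic acid on this same aromatic carbon would read in this assay. They also leave open whether a longer chain at this place would give a number clearly lower than that of compound 3.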